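The source may hold more compounds than are shown below. What is called first, only, known or untested is meant among the compounds shown, and "the series" means these compounds.

Compound 1 `COc1cc(-c2nn(-c3cccc(NC(=O)Nc4cc(C(F)(F)F)cc(C(F)(F)F)c4)c3)cc2-c2ccncc2)ccc1Cl` gives 2950 nM in a functional assay on HOP-62 cells (Homo sapiens) for inhibition, read by sulforhodamine B assay, with a stated time of 48 h; on this read-out higher numbers stand for lower toxicity in this test and lower numbers for higher toxicity in this test. Compound 2 `COc1cc(-c2nn(-c3cccc(NC(=O)Nc4cccc(C(F)(F)F)c4)c3)cc2-c2ccncc2)ccc1Cl` gives only a limit in this assay, > 50000 nM.

Compound 2 thus stands at the limit of > 50000 nM in this assay, at which 1 of the 2 values shown sits, the upper edge of the numbers shown. The step from compound 2 to compound 3 `COc1cc(-c2nn(-c3cccc(NC(=O)c4ccccc4)c3)cc2-c2ccncc2)ccc1Cl` changes (phenyl in place of (3-(trifluoromethyl)phenyl)amino on a carbonyl carbon). Within the data shown here, one measured step bears on it, an at least 16-fold higher number from compound 1 to compound 2 (1.22 log units; beyond the scatter), where the loss of a single trifluoromethyl already carried the number to the limit. Compound 3 gives up the remaining trifluoromethyl together with the amino, so no move back toward lower numbers is expected. Compound 3 is estimated at 70000 nM (range 20000 nM to 250000 nM), an expected step that the limit leaves unreadable from compound 2 to compound 3, most probably reported again only as a limit.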

Compound 3, concentration lethal to 50% of the cells: > 100000 nM
Compound 3 was reported as a limit; the forecaster's own chance of this, stated with the estimate: 85%; middle value at least 1.4-fold (0.15 log units) from the limit.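

Compound 2 and compound 3 are both reported only as limits in this assay, so no step can be read between them. Going by these compounds, whether phenyl in place of (3-(trifluoromethyl)phenyl)amino changes this read-out at all stays open.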